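A few compounds are considered here, and "the series" means these few. Any claim that something is new, unique, unknown or untested is made for them only; others in the source may bear on it.

Measured compounds:
compound 1, `S=C(N/N=C\c1ccc(Cl)cc1)N(Cc1ccccc1)Cc1ccccc1`: 159000 nM
compound 2, `C=CCN(CC=C)C(=S)N/N=C(/C)c1ccc(N)cc1`: "not determined" (no result reported)
compound 3, `C=CCN(CC=C)C(=S)N/N=C\c1ccccc1C`: > 228000 nM

Within the data shown here, in an ADME assay on Vero cells (Chlorocebus sabaeus) for cytotoxicity, read by MTT assay, with a stated time of 72 h (a lower number here means that less compound is tolerated, a higher number that more compound is tolerated), compound 1 gives 159000 nM, the only plain number in the set. Compound 2 has no result in this assay. For compound 3 the value in this assay is a limit of the assay, > 228000 nM; this is the limit of > 228000 nM in this assay, at which 1 of the 3 values shown sits. Compound 1 therefore stands as the sole fixed point, with compound 3 known only through a limit and compound 2 unknown.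

Compound 4, `Cc1ccccc1/C=N\NC(=S)N(Cc1ccccc1)Cc1ccccc1`, is not yet measured in this assay. It differs from compound 1 in one place: 2-methylphenyl in place of 4-chlorophenyl on a carbon with a double bond to nitrogen. Among the measured compounds shown here, no step between two measured compounds covers this change. For the measured compounds named here, the dibenzyl part of compound 1 is kept, and the 2-methylphenyl group is the one carried by compound 3, whose value is a limit rather than a number; nothing here fixes the direction of the step. In this assay the expected step is one that stays within the usual scatter: a 1.3-fold higher number from compound 1 to compound 4 (0.10 log units; within the scatter). Compound 4 is expected to give 200000 nM (range 80000 nM to 450000 nM) in this assay, with a fair chance that the assay returns only a limit.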

Compound 4, half-maximal cytotoxic concentration: 167000 nM
Beside the measured number, compound 4's estimate is 1.2-fold (0.08 log units) above it; the measured number falls inside the stated range.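

In this assay, the exchange on the carbon with a double bond to nitrogen reads as a 1.1-fold higher number from compound 1 to compound 4 (0.02 log units; within the scatter), so at this place 2-methylphenyl stands in for 4-chlorophenyl with no shift beyond the scatter. Among these compounds, this gives the first pair of plain numbers, with the dibenzyl part held constant: chlorine is not needed on this ring for a reading of this size, as compound 4 gives 167000 nM with a ring of carbon only. Compound 3, which carries the same 2-methylphenyl group on a diallyl part, still gives only a limit of the assay and not a number: the limit of > 228000 nM in this assay, at which 1 of the 4 values shown sits.

Steps running through compound 2 or compound 3 cannot be read, so how the dibenzyl part compares with the diallyl part in this assay stays open. A single exchange of one aromatic carbon ring for another also gives no indication of how a carboxylic acid or a nitrile on that ring would read, and the tolerance seen here rests on this one pair alone.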